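This account rests on a few compounds, and the source may have more. Where it says the series, first, only, none or still open, it means among the compounds named here.

Compound 1 `N#Cc1c(-c2ccc(Cl)cc2)nc(SCC(=O)Nn2c(COc3ccc(Cl)cc3Cl)nc3ccccc3c2=O)n(Cc2ccccc2)c1=O` and compound 2 `N#Cc1c(-c2ccc(O)cc2)nc(SCC(=O)Nn2c(COc3ccc(Cl)cc3Cl)nc3ccccc3c2=O)n(Cc2ccccc2)c1=O` share one core; compound 3 `N#Cc1c(Cl)nc(SCC(=O)Nn2c(COc3ccc(Cl)cc3Cl)nc3ccccc3c2=O)nc1-c1ccc(Cl)cc1` carries a second core, and the difference between the two cores is not broken down here. In a functional assay on the whole organism (strain albino) for inhibition, with Rattus norvegicus as the target, read by paw edema, with a stated time of 1 h, at a dose of 100 mg/kg by the oral route (a lower number here means less inhibition, a higher number more inhibition at the dose given (going by the name of the read-out)), compound 1 gives 72.7%, compound 2 gives 54.6% and compound 3 gives 63.6%; the readings of compound 3 against compound 1 and compound 2 lie within the usual scatter. Among the measured compounds shown here, the one counted step, (hydroxy in place of chloro on an aromatic carbon), made a number 18.1 percentage points lower from compound 1 to compound 2 (beyond the scatter). Compound 4 `N#Cc1c(Cl)nc(SCC(=O)Nn2c(COc3ccc(Cl)cc3Cl)nc3ccccc3c2=O)nc1-c1ccc(O)cc1` is reached from compound 3 by the same change, (hydroxy in place of chloro on an aromatic carbon), the place reading the same in both pairs. For the measured compounds named here, for compound 4 in this assay a step of the same direction and size is expected, a number 17.6 percentage points lower from compound 3 to compound 4 (beyond the scatter), resting on a number 18.1 percentage points lower from compound 1 to compound 2 (beyond the scatter) as the only measured instance of this change. Compound 4 is therefore estimated at 46%, between 35% and 58%.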

Compound 4, a percentage reported as inhibition, in the whole organism at one dose (the size of the read-out at that dose, not a potency): 72.7%
Beside the measured number, compound 4's estimate is 26.7 percentage points below it; the measured number lies above the stated range.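

In this assay, the change from 4-chlorophenyl to 4-hydroxyphenyl gave a number 9.1 percentage points higher from compound 3 to compound 4 (within the scatter), so the step seen on the core of compound 1 did not carry over to the core of compound 3: the same change on two cores in this assay, a number 18.1 percentage points lower (beyond the scatter) from compound 1 to compound 2 and a number 9.1 percentage points higher (within the scatter) from compound 3 to compound 4, 27.2 percentage points apart, beyond the scatter of two such steps

On these two pairs, a step measured on one core is therefore no safe guide to the other. This does not show a gain from hydroxy on the core of compound 3, as that step lies within the scatter, and two pairs do not show which difference between the cores matters.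

On these data alone, it remains open how an amine or a methoxy group at this place would behave on each core. A third core carrying the same change could show which of the two steps is the more typical.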